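Removing a Chloro Group in a Weakly Antiproliferative Series

A few compounds are considered here, and "the series" means these few. Any claim that something is new, unique, unknown or untested is made for them only; others in the source may bear on it.

Compound 1 `O=C1COc2ccc(-c3cccc(NS(=O)(=O)c4ccc(F)cc4)c3)cc2N1c1ccc(Cl)cc1` and compound 2 `O=C1COc2ccc(-c3cccc(NS(=O)(=O)c4ccc(F)cc4)c3)cc2N1c1ccccc1` share a core and differ in one place: hydrogen in place of chloro on an aromatic carbon. In a functional assay on A-375 cells (Homo sapiens) for antiproliferative activity, read by MTT assay, with a stated time of 72 h (on this read-out higher numbers stand for weaker inhibition and lower numbers for stronger inhibition), compound 1 gives 32500 nM. Compound 2 reaches only a limit of the assay, > 40000 nM, which is the limit of > 40000 nM in this assay, at which 1 of the 3 values shown sits. The step is an at least 1.2-fold higher number from compound 1 to compound 2 (0.09 log units; that floor lies within the scatter). Compound 3 `O=C1COc2ccc(-c3cnc(Cl)c(NS(=O)(=O)c4ccc(F)cc4)c3)cc2N1c1ccc(Cl)cc1` carries a different core, and the difference between the two cores is not broken down here. In this assay compound 3 gives 30600 nM. Compound 4 `O=C1COc2ccc(-c3cnc(Cl)c(NS(=O)(=O)c4ccc(F)cc4)c3)cc2N1c1ccccc1` is made from compound 3 by the same change, (hydrogen in place of chloro on an aromatic carbon). Since compound 1 and compound 2 show an at least 1.2-fold higher number from compound 1 to compound 2 (0.09 log units; that floor lies within the scatter), a similar small move toward weaker inhibition, possibly ending at the limit, is expected here. For compound 4 the expected step is a 1.4-fold higher number from compound 3 to compound 4 (0.14 log units; within the scatter). Compound 4 is therefore estimated at 42000 nM, between 22000 nM and 85000 nM.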

Compound 4, half-maximal inhibitory concentration: 36900 nM
Beside the measured number, compound 4's estimate is 1.1-fold (0.06 log units) above it, and the stated range covers the measured number.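

In this assay the change from 4-chlorophenyl to phenyl gives a 1.2-fold higher number from compound 3 to compound 4 (0.08 log units; within the scatter), so on this core the loss of the chloro cannot be told apart from ordinary scatter. This result does not show that the change carries over from one core to the other with the same size: the same change on two cores in this assay, an at least 1.2-fold higher number (0.09 log units; that floor lies within the scatter) from compound 1 to compound 2 and a 1.2-fold higher number (0.08 log units; within the scatter) from compound 3 to compound 4; the limit leaves it open whether they differ. Compound 2 gives a limit and not a number: the limit of > 40000 nM in this assay, at which 1 of the 4 values shown sits.

As far as these compounds go, it remains open whether an amine, a methoxy group or a carboxylic acid in place of the chloro would shift the number beyond the scatter. From the compounds shown here alone, it is also open whether the step would stay this small on a core that inhibits far more strongly.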